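The source may hold more compounds than are shown below. What is called first, only, known or untested is meant among the compounds shown, and "the series" means these compounds.

Measured so far in an assay on L cells for inhibition of Protein-serine O-palmitoleoyltransferase porcupine (Mus musculus), read by reporter gene assay, with a stated time of 24 h; on this read-out higher numbers stand for an effect only at larger amounts of compound and lower numbers for an effect already at smaller amounts:
Compound 1 `COc1ccc(-n2nc(C(=O)NCC(=O)Nc3nc4ccccc4s3)c3ccccc3c2=O)cc1`: 25000 nM
Compound 2 `O=C(CSc1nc2c(c(=O)n1-c1ccccc1)SCC2)Nc1ccc(N2CCCCC2)cc1`: 30 nM

Compound 2 stands at the lowest of the two numbers; compound 1 sits far higher, and that gap is beyond the scatter. Compound 3 `O=C(CSc1nc2c(c(=O)n1-c1ccccc1)SCC2)Nc1ccc(-c2ccncc2)cc1` keeps the core of compound 2 and differs in one place: pyridin-4-yl in place of piperidin-1-yl on an aromatic carbon. For the measured compounds named here, no comparable step has been measured, so the size of the expected step from compound 2 to compound 3 rests on the change alone. Compound 3 is expected to stay close to compound 2, with a step of about a 1.3-fold higher number from compound 2 to compound 3 (0.12 log units; within the scatter), that is, none beyond the scatter. Compound 3 is therefore estimated at 40 nM, in a range from 8 nM to 200 nM.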

Compound 3, half-maximal effective concentration: 3 nM
The estimate for compound 3 lay 13-fold (1.12 log units) above the measured number; measured number below the stated range.
By their numbers in this assay, from the lowest: compound 3; then compound 2; then compound 1.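

On an aromatic carbon para to a large group, two six-membered rings with the same counts of heavy atoms and hydrogen-bond acceptors are not interchangeable. Pyridin-4-yl in place of piperidin-1-yl gives a 10-fold lower number from compound 2 to compound 3 (1.00 log units; beyond the scatter) in this assay, so the aromatic ring goes with the lower number in this pair. Nothing at hand explains the size of this step. Still open, going by these compounds, is whether a plain phenyl ring or a pyridin-3-yl ring on this carbon would hold the lower number, and so whether the place of the ring nitrogen matters.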